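Removing a ring fluorine from a piperidine urea

A few compounds are considered here, and "the series" means these few. Any claim that something is new, unique, unknown or untested is made for them only; others in the source may bear on it.

Measured compounds:
compound 1, `O=C([C@H]1CC2CCC1C2)N1CC(c2nc(-c3ccccc3)no2)C1`, 120 nM
compound 2, `O=S(=O)(c1ccc(Cl)cc1)N1CC(c2nc(-c3cccc(Cl)c3)no2)C1`, > 10000 nM
compound 3, `O=C(N1CCC(F)CC1)N1CC(c2nc(-c3cccc(Cl)c3)no2)C1`, 990 nM

In an assay on HEK293 cells for positive allosteric modulation of metabotropic glutamate receptor 5 (Homo sapiens), read by FLIPR (a higher number here means that more compound is needed for the effect, a lower number that less compound is needed), compound 1 gives 120 nM. For compound 2 the result is only a limit of the assay, > 10000 nM, and no number is known; (the limit of > 10000 nM in this assay, at which 1 of the 3 values shown sits). Compound 3 gives 990 nM in this assay, which is the highest of the two numbers shown; the nearest is compound 1, and that gap lies beyond the usual scatter. No two of the measured compounds differ in a single place, so no measured step can be read from them.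

Compound 4, `O=C(N1CCCCC1)N1CC(c2nc(-c3cccc(Cl)c3)no2)C1`, has not yet been measured. It differs from compound 3 by hydrogen in place of fluoro on a saturated ring carbon. Going by the values given here, nothing among the measured compounds shows what such a change does in this assay. With no evidence either way, the step is expected to be small: a 1.0-fold higher number from compound 3 to compound 4 (0.00 log units; within the scatter) is estimated to stay within the scatter, in no firm direction. Compound 4 is therefore expected to give about 1000 nM in this assay, with a range from 300 nM to 3500 nM.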

Compound 4, half-maximal effective concentration: 370 nM
Compound 4: middle estimate off by 2.7-fold (0.43 log units), on the high side; measured number inside the range.
By their numbers in this assay, from the lowest: compound 1; then compound 4; then compound 3. At a limit, above all of these: compound 2.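

In this assay, replacing the fluoro on the saturated ring carbon, three ring bonds from the ring nitrogen, with hydrogen gives a 2.7-fold lower number from compound 3 to compound 4 (0.43 log units; beyond the scatter). Going by these compounds alone, this is the first change in the set that can be read on its own, and it shows that this position of the piperidine urea responds to the swap: the fluoro is not required for the effect, and the 4-fluoropiperidin-1-yl compound needs more compound than its piperidin-1-yl partner, a modest but real difference. Nothing at hand explains why the step runs in this direction or has this size.

Going by these compounds, whether a hydroxyl, a methyl or an amine on the same ring carbon would follow hydrogen or fluoro stays open, as does whether the step would keep its size and direction with a phenyl in place of the chlorophenyl group that compound 3 and compound 4 share. Within the data shown here, compound 1 and compound 2 each differ from this pair in more than one place, so no step to either of them can be read.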